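Aminoquinoline carboxamides: swapping the aminophenyl arm for an alkylamine

The source may hold more compounds than are shown below. What is called first, only, known or untested is meant among the compounds shown, and "the series" means these compounds.

Measured compounds:
compound 1, `O=C(NCc1ccc(F)cc1)c1nc(NCCO)c2cccnc2c1O`, "not determined" (no result reported) in a functional assay on HCT-116 cells (Homo sapiens) for cytotoxicity, read by MTT assay, with a stated time of 72 h; on this read-out higher numbers stand for weaker inhibition and lower numbers for stronger inhibition
compound 2, `Nc1ccc(Nc2c(C(=O)NCc3ccc(F)cc3)nc(Br)c3cccnc23)cc1`, 7000 nM

Within the data shown here, compound 2 holds the only number in this assay, where compound 2 gives 7000 nM. Compound 1 gives "not determined" (no result reported) there, so nothing can be said of the gap between the two.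

Compound 3, `CNCCCNc1c(C(=O)NCc2ccc(F)cc2)nc(Br)c2cccnc12`, is the next member to be measured. It differs from compound 2 by one change: 3-(methylamino)propyl in place of 4-aminophenyl on a nitrogen on an aromatic ring. Among the measured compounds shown here, no measured pair shows the effect of such a change, so there is no step from which to read a direction.

With a single number to go on, the expected step from compound 2 to compound 3 in this assay is a 1.2-fold lower number from compound 2 to compound 3 (0.07 log units; within the scatter), not beyond the usual scatter. Compound 3 is therefore expected to give 6000 nM, within the range 1500 nM to 25000 nM.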

Compound 3, half-maximal inhibitory concentration: > 10000 nM
Compound 3: only a limit was reported; the forecaster's own chance of this, stated with the estimate: 15%; middle value at least 1.6-fold (0.22 log units) away from the limit.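

In this assay compound 3 gives > 10000 nM, which is a limit of the assay and not a number. Among these compounds, this gives the first step at this place, on a nitrogen on an aromatic ring: 3-(methylamino)propyl in place of 4-aminophenyl gives an at least 1.4-fold higher number from compound 2 to compound 3 (0.15 log units; that floor lies within the scatter), so the alkylamine arm shows no sign of a lower number, though the size of the step remains unfixed. The step therefore rests on a limit rather than a measured endpoint: the limit of > 10000 nM in this assay, at which 1 of the 3 values shown sits.

The compounds shown leave open whether the result follows the loss of the six-membered aromatic ring or the change in the arm as a whole. An unsubstituted phenyl group or a shorter alkylamine chain on the same nitrogen would help separate these two readings.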